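This account rests on a few compounds, and the source may have more. Where it says the series, first, only, none or still open, it means among the compounds named here.

Measured compounds:
compound 1 `c1ccc(CNCc2cn(Cc3ccccc3)c3ccccc23)cc1`: 245000 nM
compound 2 `CC#CCN(C)Cc1cc2cc(O)ccc2n1C`: 5.75 nM
compound 3 `C#CCN(C)Cc1cc2cc(O)ccc2n1C`: 3.98 nM

In an assay on isolated protein for inhibition of Amine oxidase [flavin-containing] A (Rattus norvegicus) (a higher number here means a weaker inhibitor, a lower number a stronger inhibitor), compound 1 gives 245000 nM, the highest of the three numbers and therefore the weakest inhibitor here, far beyond the scatter from compounds 2 and 3. Compound 2 gives 5.75 nM and compound 3 gives 3.98 nM. Among the measured compounds shown here, the only one-step comparison among the measured compounds, a 1.4-fold lower number from compound 2 to compound 3 (0.16 log units; within the scatter), concerns a hydrogen in place of methyl on a triple-bonded carbon of a different core, so it does not speak to the change examined now.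

Compound 4 `CCNCc1cn(Cc2ccccc2)c2ccccc12` differs from compound 1 by methyl in place of phenyl on a saturated chain carbon bound to an amine nitrogen, that is, benzyl to ethyl. For the measured compounds named here, no measured step touches this kind of change, so the expectation rests on compound 1 alone, with wide uncertainty. The step is expected to be a 1.2-fold lower number from compound 1 to compound 4 (0.09 log units; within the scatter), no clear direction beyond the scatter. Compound 4 is thus estimated at 200000 nM, within a range from 50000 nM to 800000 nM.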

Compound 4, inhibition constant: 263000 nM
Compound 4: middle estimate off by 1.3-fold (0.12 log units), on the low side; the range from low to high includes it.
By their numbers in this assay, from the lowest: compounds 3 and 2 (each within the scatter of the next); then compounds 1 and 4 (each within the scatter of the next).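

In this assay, exchanging benzyl for ethyl, which puts methyl in place of phenyl on a saturated chain carbon bound to an amine nitrogen, gives a 1.1-fold higher number from compound 1 to compound 4 (0.03 log units; within the scatter). At this position, then, a whole six-membered aromatic ring can be exchanged for a single carbon with no difference that can be told from the scatter, something the earlier step, made at a triple-bonded carbon on a different core, could not show. No information is available that would explain this result.

As far as these compounds go, whether a hydroxyl, a carboxylic acid or a longer chain such as butyl at this place would shift the number remains open. So does whether the same exchange would give as small a step on the core of compound 3.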